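The source may report more compounds than this note shows. Statements on the series, on what has been measured and on what is new or still open speak of the compounds shown alone.

In a functional assay on HepG2 cells (Homo sapiens) for inhibition, read by fluorescence and resazurin assay, with a stated time of 72 h (a lower number here means a stronger inhibitor, a higher number a weaker inhibitor), compound 1 `O=C(Nc1ccccc1)Nc1cccc(Nc2nccc(Nc3ccc4nc[nH]c4c3)n2)c1` gives 11000 nM while compound 2 `O=C(Nc1ccccc1)Nc1cccc(Nc2nccc(Nc3ccc4[nH]ncc4c3)n2)c1` gives 8100 nM and compound 3 `O=C(Nc1ccccc1)Nc1cccc(Nc2nccc(Nc3ccc4[nH]ccc4c3)n2)c1` gives 5000 nM with the rest of the structure unchanged. The standing of compound 3 rests on two steps: a 1.6-fold lower number from compound 2 to compound 3 (0.21 log units; within the scatter) and a 2.2-fold lower number from compound 1 to compound 3 (0.34 log units; beyond the scatter) in this small set. It is therefore separated from only one of the other two compounds, and only modestly.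

Compound 4 `O=C(Nc1ccccc1)Nc1cccc(Nc2nccc(Nc3ccc4cc[nH]c4c3)n2)c1` has the same atoms as compound 3, joined differently (1H-indol-6-yl in place of 1H-indol-5-yl on a nitrogen on an aromatic ring). In words, it carries 1H-indol-6-yl in place of 1H-indol-5-yl on a nitrogen on an aromatic ring.

For the measured compounds named here, no measured step moves the attachment point of a group in this way. The nearest evidence comes from swapping one ring group for another at that same place: a 1.4-fold lower number from compound 1 to compound 2 (0.13 log units; within the scatter) joins the two steps above, and none of the three is more than modest. This is a thin basis for a forecast, but it offers no reason to expect a large change. In this assay no step beyond the scatter is expected, and neither direction is favoured. The estimate amounts to a 1.2-fold higher number from compound 3 to compound 4 (0.08 log units; within the scatter) as the expected step. Compound 4 is expected to read about 6000 nM within an estimated range from 2500 nM to 14000 nM in this measurement.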

Compound 4, half-maximal inhibitory concentration in the HepG2 assay: 3200 nM
The estimate for compound 4 lay 1.9-fold (0.27 log units) above the measured number; the range from low to high includes it.
By their numbers in the HepG2 assay, from the lowest: compounds 4, 3, 2 and 1 (each within the scatter of the next, the first and the last beyond it).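

Moving the attachment point on the aromatic nitrogen, from 1H-indol-5-yl to 1H-indol-6-yl, gives in the HepG2 assay a 1.6-fold lower number from compound 3 to compound 4 (0.19 log units; within the scatter), so this position tolerates the shift without a change that can be told from the scatter. Even so, the HepG2 assay now shows a 2.5-fold lower number from compound 2 to compound 4 (0.40 log units; beyond the scatter) and a 3.4-fold lower number from compound 1 to compound 4 (0.54 log units; beyond the scatter), which places compound 4 clearly apart from both ring groups that carry extra ring nitrogen, whereas compound 3 stood clear of only one of them. The same shift also leaves the second property unresolved: in a physicochemical assay for solubility, read by HPLC, in phosphate buffer, at pH 7.4 (a lower number here means a less soluble compound, a higher number a more soluble compound), compound 3 gives 0.33 ug/mL and compound 4 gives 0.44 ug/mL, and a 1.3-fold higher number from compound 3 to compound 4 (0.12 log units; within the scatter) does not separate the two.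

No data shown here give a cause for any of these readings. On these data alone, it remains open whether 1H-indazol-6-yl would read differently from the 1H-indazol-5-yl of compound 2, and whether an amine or a carboxylic acid carried on the 1H-indol-6-yl group would shift either of the two read-outs beyond the scatter.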